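Propargyl in place of ethynyl: expected lipophilicity step

A few compounds are considered here, and "the series" means these few. Any claim that something is new, unique, unknown or untested is made for them only; others in the source may bear on it.

In a physicochemical assay for lipophilicity (on this read-out higher numbers stand for higher lipophilicity and lower numbers for lower lipophilicity), compound 1 `C#CC(CC)OC[n+]1ccn(C)c1/C=N/O` gives -1.49 and compound 2 `C#CC(CCC)OC[n+]1ccn(C)c1/C=N/O` gives -1.1, the higher of the two numbers. Compound 3 `C#CCC(CCC)OC[n+]1ccn(C)c1/C=N/O` has propargyl in place of ethynyl on a saturated chain carbon bound to an oxygen on a saturated carbon and a saturated chain carbon. Within the data shown here, only one measured step bears on this, a different change of methyl in place of hydrogen on a saturated chain carbon, a modest rise beyond the scatter of a number 0.39 log units higher from compound 1 to compound 2 (beyond the scatter). An upward step of similar size is therefore expected, a number 0.35 log units higher from compound 2 to compound 3 (beyond the scatter). In this assay the estimated value for compound 3 is -0.75, with an expected range of -1 to -0.5.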

Compound 3, distribution coefficient: -1.17
Beside the measured number, compound 3's estimate is 0.42 log units above it, outside the stated range (below it).
By their numbers in this assay, from the lowest: compound 1; then compounds 3 and 2 (each within the scatter of the next).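

In this assay, a number 0.07 log units lower from compound 2 to compound 3 (within the scatter) is the step for propargyl in place of ethynyl on a saturated chain carbon bound to an oxygen on a saturated carbon and a saturated chain carbon. This change therefore leaves compounds 2 and 3 indistinguishable on this read-out, whereas the methyl change, a number 0.39 log units higher from compound 1 to compound 2 (beyond the scatter), lies beyond the scatter. No available data account for this difference between the two steps.

Open, on these data alone, is whether a longer chain or an amine in place of ethynyl at this carbon would move the number beyond the scatter of compound 2. Also open, as far as these compounds go, is whether propargyl in place of ethynyl gives a comparable step on the shorter chain of compound 1.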